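Turning the Chlorophenyl Group on an Imine

The compounds below may be only part of what the source reports. "The series", "measured", "known", "first", "only" and "open" are said of these compounds alone.

Of the compounds shown here, three that share one core have been tested in an ADME assay on HepG2 cells (Homo sapiens) for cytotoxicity, read by MTT assay, with a stated time of 72 h; a higher number here means that more compound is tolerated, a lower number that less compound is tolerated. Compound 1 `Nc1sc2c(c1-c1nc3cc(Cl)ccc3s1)CCCC2` gives 93.7 ug/mL in this assay. Compound 2 `C(=C/c1ccccc1)\C=N\c1sc2c(c1-c1nc3ccccc3s1)CCC2` gives 215 ug/mL in this assay. Compound 3 `Clc1ccc(/C=N/c2sc3c(c2-c2nc4ccccc4s2)CCCC3)cc1` gives 397 ug/mL in this assay, the highest of the three numbers. The gap from compound 3 down to compound 2 lies within the usual scatter, so those two cannot be told apart; the gap down to compound 1 lies beyond it, so compound 3 is tolerated in larger amounts than compound 1.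

Compound 4 `Clc1ccccc1/C=N/c1sc2c(c1-c1nc3ccccc3s1)CCCC2` has not been measured. It differs from compound 3 in one place: 2-chlorophenyl in place of 4-chlorophenyl on a carbon with a double bond to nitrogen. Among the compounds with values here, no measured pair shows a change of this kind, so there is no guide to its effect. For compound 4 the expected step is a 1.1-fold lower number from compound 3 to compound 4 (0.05 log units; within the scatter), in no set direction and not beyond the scatter. Compound 4 is thus expected to give about 350 ug/mL in this assay, within a range from 150 ug/mL to 700 ug/mL.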

Compound 4, half-maximal cytotoxic concentration: 370 ug/mL
Estimate against measurement, compound 4: 1.1-fold (0.02 log units) below; low and high end bracket the measured number.
By their numbers in this assay, from the lowest: compound 1; then compounds 2, 4 and 3 (each within the scatter of the next).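

Within the data shown here, replacing 4-chlorophenyl with 2-chlorophenyl on the carbon with a double bond to nitrogen gives the first pair of compounds here that differ in one place. In this assay the result is a 1.1-fold lower number from compound 3 to compound 4 (0.03 log units; within the scatter), so the two cannot be told apart. For this pair, moving the chlorine on the phenyl ring makes no difference that the assay can detect, and nothing shown here bears on why.

On these data alone, what stays open is whether this position is equally indifferent to groups other than chlorine, such as a methoxy group or a carboxylic acid on the phenyl ring. The gap between compound 3 and compound 1 also cannot be traced to any single change, as those two differ in more than one place.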